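Swapping a Fluorophenyl for a Methoxyphenoxy Group

A few compounds are considered here, and "the series" means these few. Any claim that something is new, unique, unknown or untested is made for them only; others in the source may bear on it.

This account follows a single change made on the shared core of compound 1 `Fc1ccc(-c2ccc3c(NCCCNCc4ccco4)ccnc3c2)cc1`. In an ADME assay for permeability, using PAMPA, with a stated time of 30 min, at pH 7.4 (on this read-out lower numbers stand for lower permeability and higher numbers for higher permeability), compound 1 gives 237 10^-6 cm/s. Compound 2 `COc1cccc(CNCCCNc2ccnc3cc(-c4ccccc4)ccc23)c1O`, measured in this assay, gives 237 10^-6 cm/s, so compound 1 stands level with compound 2 at the digits shown, and the two differ by nothing beyond the scatter. Compound 3 `COc1ccc(Oc2ccc3c(NCCCNCc4ccco4)ccnc3c2)cc1` has not yet been measured in this assay. It differs from compound 1 as follows: 4-methoxyphenoxy in place of 4-fluorophenyl on an aromatic carbon. For the measured compounds named here, no step between measured compounds bears on this change, so only an expectation can be offered. A modest move downward in this assay is expected, though it may well sit within the scatter. The expected step is a 1.3-fold lower number from compound 1 to compound 3 (0.12 log units; within the scatter). For compound 3 the estimated value in this assay is 180 10^-6 cm/s, within a range from 90 10^-6 cm/s to 320 10^-6 cm/s.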

Compound 3, apparent permeability: 317 10^-6 cm/s
Compound 3: middle estimate off by 1.8-fold (0.25 log units), on the low side, within the range that was stated.
By their numbers in this assay, from the lowest: compounds 1, 2 and 3 (each within the scatter of the next).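

In this assay, 4-methoxyphenoxy in place of 4-fluorophenyl on an aromatic carbon gives a 1.3-fold higher number from compound 1 to compound 3 (0.13 log units; within the scatter), so this read-out does not separate the two groups at this position. The exchange takes the group at this position from 7 heavy atoms to 9 and from 0 hydrogen-bond acceptors to 2, and the number for the new compound still lies within the scatter of the old one. Nothing measured here offers an explanation for this result.

The change alters two things at once, and the compounds shown cannot separate the oxygen link from the methoxy group, which a plain phenoxy or a 4-methoxyphenyl group could address. Also open, going by these compounds, is how a group of another kind at this position, such as an amine or a carboxylic acid, would read in this assay.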